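Phenyl in Place of Pyridinyl on a Porcupine Inhibitor

This account rests on a few compounds, and the source may have more. Where it says the series, first, only, none or still open, it means among the compounds named here.

Measured compounds:
compound 1, `CN1C(=O)C2=C(C1=O)N(CC(=O)Nc1ccc(-c3ccccc3)cn1)CCC2`: 1 nM
compound 2, `CN1C(=O)C2=C(C1=O)N(CC(=O)Nc1ccc(-c3cccnc3)nn1)CCC2`: 29 nM

In an assay on cells for inhibition of Protein-serine O-palmitoleoyltransferase porcupine (Homo sapiens), read by reporter gene assay (on this read-out lower numbers stand for stronger inhibition and higher numbers for weaker inhibition), compound 1 gives 1 nM. In the same assay compound 2 gives 29 nM, the higher of the two numbers, and its gap to compound 1, the nearer of the two, lies beyond the scatter.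

Compound 3, `CN1C(=O)C2=C(C1=O)N(CC(=O)Nc1ccc(-c3ccccc3)nn1)CCC2`, is not yet measured. It differs from compound 2 in one place: phenyl in place of pyridin-3-yl on an aromatic carbon. For the measured compounds named here, no measured pair shows this change alone. Compound 1 also carries a phenyl at this position and gives 1 nM, but it differs from compound 2 in more than this one place, so that value is only a loose guide.

A step toward a lower number, beyond the scatter, is expected, with the step from compound 2 to compound 3 estimated as a 3.6-fold lower number from compound 2 to compound 3 (0.56 log units; beyond the scatter). Compound 3 is expected to give 8 nM, in a range from 2 nM to 40 nM.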

Compound 3, half-maximal inhibitory concentration in the Protein-serine O-palmitoleoyltransferase porcupine assay: 1 nM
Estimate against measurement, compound 3: 8.0-fold (0.90 log units) above; measured number outside the range, below it.
By their numbers in the Protein-serine O-palmitoleoyltransferase porcupine assay, from the lowest: compounds 1 and 3 (each within the scatter of the next); then compound 2.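

In the Protein-serine O-palmitoleoyltransferase porcupine assay, phenyl in place of pyridin-3-yl on this aromatic carbon, with the rest of the molecule unchanged, gives a 29-fold lower number from compound 2 to compound 3 (1.46 log units; beyond the scatter). The position is therefore highly sensitive in this assay: exchanging the ring nitrogen of the pyridin-3-yl for carbon is enough to produce a large step. In a physicochemical assay for solubility, measured as thermodynamic solubility, at pH 7.4 (a higher number here means a more soluble compound, a lower number a less soluble compound), compound 2 gives 9.5 ug/mL and compound 3 gives 3.34 ug/mL. The same change has a cost in the physicochemical assay: the measured solubility of compound 2, 9.5 ug/mL, and of compound 3, 3.34 ug/mL, a 2.8-fold lower number (0.45 log units; beyond the scatter)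

What pyridin-2-yl or pyridin-4-yl would give in this place remains open, so the compounds shown do not tell whether any ring nitrogen in this group has the same effect in the Protein-serine O-palmitoleoyltransferase porcupine assay. Also open, as far as these compounds go, is whether an amine or a methoxy group on the phenyl could raise the number in the physicochemical assay while keeping the low number in the Protein-serine O-palmitoleoyltransferase porcupine assay.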